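Swapping the aryl group on the cyano-pyridinone core

The source may hold more compounds than are shown below. What is called first, only, known or untested is meant among the compounds shown, and "the series" means these compounds.

This account follows two measured compounds and one that is not yet measured, all sharing one core. Compound 1 `COc1ccc(-c2cc(-c3cc(C(C)C)c(O)cc3C)[nH]c(=O)c2C#N)c(OC)c1` and compound 2 `COc1cc(OC)c(-c2cc(-c3cc(C(C)C)c(O)cc3C)[nH]c(=O)c2C#N)c(OC)c1` differ in one place. In a functional assay for inhibition, tested at 100 ug/mL (on this read-out lower numbers stand for a weaker effect and higher numbers for a stronger effect at the one concentration tested), compound 1 gives 58% and compound 2 gives 82.5%. For the measured compounds named here, the single measured step, methoxy in place of hydrogen on an aromatic carbon, is a number 24.5 percentage points higher from compound 1 to compound 2 (beyond the scatter). Going by the values given here, compound 1 therefore stands lowest of the two numbers known, with compound 2 as its only neighbour.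

Compound 3 `Cc1cc(O)c(C(C)C)cc1-c1cc(-c2ccc(N(C)C)cc2)c(C#N)c(=O)[nH]1` is the one still to be measured. It differs from compound 1 as follows: 4-(dimethylamino)phenyl in place of 2,4-dimethoxyphenyl on an aromatic carbon. Among the compounds with values here, no measured step covers this kind of change; the only step known, from compound 1 to compound 2, concerns a methoxy added to the aryl ring that leaves here, and it does not tell what a 4-(dimethylamino)phenyl will do in place of a 2,4-dimethoxyphenyl. The direction is thus open, and the expectation stays close to compound 1 with a wide range. Compound 3 is expected to give about 55% in this assay, between 30% and 80%, a step of a number 3 percentage points lower from compound 1 to compound 3 (within the scatter).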

Compound 3, a percentage reported as inhibition, at one concentration (the size of the read-out at that concentration, not a potency): 68%
Compound 3: the middle estimate sits 13 percentage points below what was measured, and the stated range covers the measured number.
By their numbers in this assay, from the lowest: compounds 1 and 3 (each within the scatter of the next); then compound 2.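

At the aromatic carbon opposite the ring nitrogen, in this assay, 4-(dimethylamino)phenyl can take the place of 2,4-dimethoxyphenyl with a number 10 percentage points higher from compound 1 to compound 3 (within the scatter). The earlier compounds shown here varied only the methoxy pattern on the aryl ring, whereas compound 3 carries no methoxy group at all and still gives a read-out that cannot be told apart from that of compound 1, so an effect of this size at the one concentration tested does not depend on those methoxy groups in this pair. Nothing shown here explains this result, and no measurement on the two aryl groups bears on it.

The compounds shown leave open whether a single methoxy or a single dimethylamino group, placed on the aryl ring in other ways, would stay level with compound 1 or would move the read-out as far as the added methoxy did in compound 2. They also leave open what a carboxylic acid, a morpholine or a longer alkyl chain on that ring would give, and how any of these compounds would behave at other concentrations.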